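Dropping an ester-bearing group from compound 1

The source may report more compounds than this note shows. Statements on the series, on what has been measured and on what is new or still open speak of the compounds shown alone.

Measured so far, in a functional assay for inhibition, with Homo sapiens as the target; a higher number here means a weaker inhibitor, a lower number a stronger inhibitor:
compound 1 `CCOC(=O)C(=O)N(c1ccccc1)c1nccc(-c2ccncc2)n1` gives 2200 nM
compound 2 `CC(=O)Nc1ccc(Nc2nccc(-c3cccnc3)n2)cc1` gives 3600 nM
compound 3 `Oc1ccc(Nc2nccc(-c3cccnc3)n2)cc1` gives 5100 nM

Compound 1 has the lowest number of the three; compound 2 lies within the scatter of it, compound 3 beyond it. Among the measured compounds shown here, the only measured step, a 1.4-fold higher number from compound 2 to compound 3 (0.15 log units; within the scatter), changes a group on an aromatic carbon and says nothing about the nitrogen. Compound 4 `c1ccc(Nc2nccc(-c3ccncc3)n2)cc1` differs from compound 1 in one place: hydrogen in place of (ethoxycarbonyl)carbonyl on a nitrogen on an aromatic ring. For the measured compounds named here, no measured step bears on this change, so the expectation rests only on compounds 2 and 3, whose free nitrogen gives numbers close to compound 1. For compound 4 a step of a 1.2-fold lower number from compound 1 to compound 4 (0.09 log units; within the scatter) is expected, not beyond the scatter. Compound 4 is estimated at 1800 nM, between 600 nM and 5500 nM.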

Compound 4, half-maximal inhibitory concentration: 900 nM
Compound 4: the middle estimate sits 2.0-fold (0.30 log units) above what was measured; the measured number falls inside the stated range.
By their numbers in this assay, from the lowest: compound 4; then compounds 1, 2 and 3 (each within the scatter of the next, the first and the last beyond it).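

In this assay, hydrogen in place of (ethoxycarbonyl)carbonyl gives a 2.4-fold lower number from compound 1 to compound 4 (0.39 log units; beyond the scatter). Among the compounds shown here, this is the first step at the nitrogen on an aromatic ring, and it shows that the group on this nitrogen can move the number beyond the scatter, with the free nitrogen giving the lower number. Nothing available explains this difference. The compounds shown leave open how a smaller group on this nitrogen, such as methyl or acetyl, would compare. They also leave open whether a carboxylic acid in place of the ethyl ester would keep the number of compound 1.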